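Swapping an amide-bearing side chain for an imidazole-bearing one

The compounds below may be only part of what the source reports. "The series", "measured", "known", "first", "only" and "open" are said of these compounds alone.

Of the compounds shown here, two with a shared core have been measured for how much of an oral dose reaches the bloodstream of rats. In an ADME assay on the whole organism (strain Sprague-Dawley) for pharmacokinetics, with Rattus norvegicus as the target, read by LC-MS (on this read-out higher numbers stand for higher oral bioavailability and lower numbers for lower oral bioavailability), compound 1 `O=C(COc1nn(-c2ccccc2F)c2ccc(F)cc12)N1CCOCC1` gives 22%, the lower of the two numbers on record. Compound 2 `CC(C)(C)OC(=O)N1CCN(c2cccc3c2cnn3-c2ccccc2F)C1=O` reaches 100% in this assay, a value that lies beyond the usual scatter above compound 1. For the measured compounds named here, compound 2 differs from compound 1 in more than one place, so its number shows only that the shared core can support high oral uptake; no single structural step between measured compounds is available.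

Compound 3 `Fc1ccc2c(c1)c(OCCn1ccnc1)nn2-c1ccccc1F` is the next compound to be measured. It is built from compound 1 by the change ((1H-imidazol-1-yl)methyl in place of (morpholin-4-yl)carbonyl on a saturated chain carbon bound to an oxygen on an aromatic ring). Going by the values given here, no measured pair isolates this change. Any expectation therefore rests on compound 1 alone and on the knowledge that the core itself is compatible with far higher values.

The step from compound 1 to compound 3 in this assay is expected to be a modest rise, a number 13 percentage points higher from compound 1 to compound 3 (beyond the scatter), though it may also fall within the scatter. Compound 3 is estimated to give 35% in this assay, with a likely range from 10% to 70%.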

Compound 3, oral bioavailability: 28%
Beside the measured number, compound 3's estimate is 7 percentage points above it; low and high end bracket the measured number.
By their numbers in this assay, from the lowest: compounds 1 and 3 (each within the scatter of the next); then compound 2.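

For the compounds shown here, compound 3 gives the first comparison in which only one place changes: the ((morpholin-4-yl)carbonyl)methyl group on the oxygen of the shared core becomes a 2-(1H-imidazol-1-yl)ethyl group, and in this assay this change reads as a number 6 percentage points higher from compound 1 to compound 3 (within the scatter), so the two side chains cannot be told apart on this read-out. At this position, then, the morpholine ring and the carbonyl can be exchanged for an imidazole ring without a shift that stands out from the differences seen between repeated measurements. No measurement at hand explains why these two quite different side chains give such similar readings.

This single exchange leaves open whether any group at this position can move oral bioavailability beyond the scatter, for instance a carboxylic acid or a primary amine at the end of the chain, or a longer chain carrying the imidazole. It also leaves open which of the several structural differences in compound 2 goes with its much higher number, since no series of single changes connects it to compound 1 or compound 3.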